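Swapping a pyrazole for a nitrophenyl on a pyrazole acid core

A few compounds are considered here, and "the series" means these few. Any claim that something is new, unique, unknown or untested is made for them only; others in the source may bear on it.

The series rests on a shared core that carries a carboxy group, a methyl group and a thiazole bearing an isopropylsulfanyl group. Compound 1 `Cc1c(-c2cc(Cl)cc(Cl)c2)c(C(=O)O)nn1-c1nc(-c2cccnc2)c(SC(C)C)s1` is reported as "not active" (no number reported) in a functional assay on BJAB cells (Homo sapiens) for antiproliferative activity, with a stated time of 4 days (on this read-out lower numbers stand for an effect already at smaller amounts and higher numbers for an effect only at larger amounts of compound), so no number is available for it. Within the data shown here, compound 2 `Cc1nn(-c2nc(-c3ccc(Cl)c(Cl)c3)c(SC(C)C)s2)c(C(=O)O)c1-c1cnn(C)c1` gives 6800 nM in this assay, and this is the only numerical value shown for the set; one further entry stands without a single number, so compound 2 cannot be ranked against anything measured.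

Compound 3 `Cc1nn(-c2nc(-c3ccc(Cl)c(Cl)c3)c(SC(C)C)s2)c(C(=O)O)c1-c1ccccc1[N+](=O)[O-]` differs from compound 2 in one place: 2-nitrophenyl in place of 1-methyl-1H-pyrazol-4-yl on an aromatic carbon. Among the measured compounds shown here, no pair of measured compounds shows such a change, so its effect cannot be read from the data. For the measured compounds named here, with only one number in hand, the step from compound 2 to compound 3 is expected to be small, most likely within the usual scatter, and the estimate is a 1.1-fold lower number from compound 2 to compound 3 (0.05 log units; within the scatter) in this assay. Compound 3 is therefore expected to give about 6000 nM, with a plausible range from 1500 nM to 25000 nM.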

Compound 3, half-maximal effective concentration: 4700 nM
Beside the measured number, compound 3's estimate is 1.3-fold (0.11 log units) above it; the range from low to high includes it.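

In this assay, among these compounds, the exchange of 1-methyl-1H-pyrazol-4-yl for 2-nitrophenyl, on the aromatic carbon next to the ring atom that bears a carboxy group, gives a 1.4-fold lower number from compound 2 to compound 3 (0.16 log units; within the scatter), the first step that can be read at this position. The numbers of the two compounds therefore cannot be told apart, even though a six-membered aromatic ring of carbon only, with its nitro group and 9 heavy atoms, takes the place of a five-membered aromatic ring with 2 hetero atoms and 6 heavy atoms. No measurement of any property of these two groups accompanies this result, so the step stands without an explanation.

Compound 1 carries no number and differs from the other two compounds in more than one place, so steps involving it cannot be read. The compounds shown leave open whether a plain phenyl, a 2-aminophenyl or a 2-carboxyphenyl group at this position would give a number beyond the scatter from compound 2, and whether the nitro group would matter if it stood elsewhere on the phenyl ring, as in 4-nitrophenyl.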